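Para-substituted acrylamides: removing the chloro group

The compounds below may be only part of what the source reports. "The series", "measured", "known", "first", "only" and "open" are said of these compounds alone.

Measured so far in a toxicity assay on the whole organism (strain Icem-CET (SPF Caw)) for cytotoxicity, with Mus musculus as the target; a higher number here means that more compound is needed for the effect, a lower number that less compound is needed:
compound 1, `C=CCNC(=O)/C(C)=C(\C)c1ccc(OC)cc1` — 300 mg/kg
compound 2, `C=CCNC(=O)/C(C)=C(\C)c1ccc(Cl)cc1` — 90 mg/kg

In this assay compound 1 gives 300 mg/kg, and compound 2 gives 90 mg/kg. Compound 2 holds the lowest of the two numbers; its nearest neighbour is compound 1, which stands higher. Going by the values given here, the one measured step, a 3.3-fold lower number from compound 1 to compound 2 (0.52 log units; beyond the scatter), carries chloro in place of methoxy on an aromatic carbon, para to a large group.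

Compound 3, `C=CCNC(=O)/C(C)=C(\C)c1ccccc1`, has not yet been tested in this assay. It differs from compound 2 by hydrogen in place of chloro on an aromatic carbon. The step from compound 1 to compound 2 is the only one that bears on it: it touches the same aromatic position, and its size was modest. Compound 2 sits at the lowest number, 90 mg/kg, and compound 3 no longer carries the chloro that set it apart; a number between those of compound 2 and compound 1 is therefore expected, with the direction uncertain. For compound 3 a value of 160 mg/kg is estimated, in the range 70 mg/kg to 350 mg/kg. This estimate corresponds to an expected step of a 1.8-fold higher number from compound 2 to compound 3 (0.25 log units; within the scatter).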

Compound 3, dose for half-maximal effect: 300 mg/kg
Compound 3: middle estimate off by 1.9-fold (0.27 log units), on the low side; low and high end bracket the measured number.
By their numbers in this assay, from the lowest: compound 2; then compounds 1 and 3 (each within the scatter of the next).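

In this assay, hydrogen in place of chloro on the aromatic carbon gives a 3.3-fold higher number from compound 2 to compound 3 (0.52 log units; beyond the scatter), so the lower number of compound 2 goes with the chloro group and is lost when that group leaves, rather than being a feature of the shared core. Hydrogen in place of methoxy at the same position gives no change at the digits printed from compound 1 to compound 3 (within the scatter), which means that methoxy and hydrogen cannot be told apart here and that the earlier step from methoxy to chloro is better read as a change brought by chloro than as one brought by the loss of methoxy. Among these three compounds chloro alone stands apart, and nothing at hand gives a reason for this.

Three groups at one position do not show whether the lower number is specific to chloro or is shared by other groups placed there, such as fluoro, bromo, methyl or an amine. From the compounds shown here alone, it also remains open whether the effect of chloro holds when the allyl chain on the amide nitrogen gives way to a longer chain or a carboxylic acid is present on it.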